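The source may hold more compounds than are shown below. What is called first, only, known or untested is meant among the compounds shown, and "the series" means these compounds.

Measured compounds:
Compound 1 `CC(=O)Nc1ccc(S(=O)(=O)NC(C)c2nc3ccccc3c(=O)n2/N=C/c2cccc([N+](=O)[O-])c2)cc1` gives 0.053 ug/mL in an assay for inhibition of Dihydrofolate reductase (Bos taurus), with a stated time of 2 min; a lower number here means a stronger inhibitor, a higher number a weaker inhibitor.
Compound 2 `CC(=O)Nc1ccc(S(=O)(=O)NC(C)c2nc3ccccc3c(=O)n2/N=C/c2cccc(F)c2)cc1` gives 0.027 ug/mL in this assay.

Compound 1 stands with the highest of the two numbers, and its nearest neighbour is compound 2, separated from it by the step of a 2.0-fold lower number from compound 1 to compound 2 (0.29 log units; within the scatter). Compound 3 `CC(=O)Nc1ccc(S(=O)(=O)NC(C)c2nc3ccccc3c(=O)n2/N=C/c2ccc(F)cc2)cc1` has not yet been measured. It differs from compound 1 in one place: 4-fluorophenyl in place of 3-nitrophenyl on a carbon with a double bond to nitrogen. Among the measured compounds shown here, the only measured step that bears on this change is a 2.0-fold lower number from compound 1 to compound 2 (0.29 log units; within the scatter), which also exchanges the nitro group for a fluoro, and that step stayed within the scatter. A change of the same kind in compound 3 is therefore expected to give a step of about a 1.5-fold lower number from compound 1 to compound 3 (0.18 log units; within the scatter) in this assay, again within the scatter, if anything toward a lower number. For compound 3 the estimate is 0.035 ug/mL, with a range from 0.012 ug/mL to 0.1 ug/mL.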

Compound 3, half-maximal inhibitory concentration: 0.034 ug/mL
Compound 3: the middle estimate sits 1.0-fold (0.01 log units) above what was measured; low and high end bracket the measured number.
By their numbers in this assay, from the lowest: compounds 2, 3 and 1 (each within the scatter of the next).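

In this assay, 4-fluorophenyl in place of 3-nitrophenyl on a carbon with a double bond to nitrogen gives a 1.6-fold lower number from compound 1 to compound 3 (0.19 log units; within the scatter), while 4-fluorophenyl in place of 3-fluorophenyl at the same place gives a 1.3-fold higher number from compound 2 to compound 3 (0.10 log units; within the scatter). Both steps lie within the scatter, so the new result extends the earlier picture: the exchange of nitro for fluoro now comes with a second placing of the fluoro, and 3-nitrophenyl, 3-fluorophenyl and 4-fluorophenyl cannot be told apart at this position. No available evidence accounts for this flat response.

The compounds shown leave open whether it would hold for a phenyl ring carrying an amine or a carboxylic acid, or for a longer alkyl chain in place of the ring. They also leave open how much the shared core contributes, as all three compounds carry it unchanged.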